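Replacing fluorophenyl with a hydroxylated ring in a curcumin-like scaffold

The source may report more compounds than this note shows. Statements on the series, on what has been measured and on what is new or still open speak of the compounds shown alone.

Compound 1 `COc1cccc(/C=C/C(=O)C(=Cc2ccc(F)cc2)C(=O)/C=C/c2cccc(OC)c2OC)c1OC` gives 340 nM in a functional assay on A549 cells (Homo sapiens) for antiproliferative activity, read by sulforhodamine B assay, with a stated time of 48 h (a lower number here means a stronger inhibitor, a higher number a weaker inhibitor), the lowest of the two numbers measured, while compound 2 `COc1cc(OC)c(C=C(C(=O)/C=C/c2cccc(OC)c2OC)C(=O)/C=C/c2cccc(OC)c2OC)c(OC)c1` gives 630 nM. Within the data shown here, the one step at the same position, a 1.9-fold higher number from compound 1 to compound 2 (0.27 log units; within the scatter), stayed within the scatter. Compound 3 `COc1cccc(/C=C/C(=O)C(=Cc2ccc(O)c(F)c2)C(=O)/C=C/c2cccc(OC)c2OC)c1OC` differs from compound 1 by 3-fluoro-4-hydroxyphenyl in place of 4-fluorophenyl on a double-bonded chain carbon bound to a double-bonded chain carbon. Because a 1.9-fold higher number from compound 1 to compound 2 (0.27 log units; within the scatter) was within the scatter for a different ring at that place, no step beyond the scatter is expected for compound 3, and the estimated change is a 1.1-fold lower number from compound 1 to compound 3 (0.05 log units; within the scatter). Compound 3 is therefore expected to give 300 nM, within a range from 120 nM to 750 nM.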

Compound 3, half-maximal inhibitory concentration: 200 nM
Beside the measured number, compound 3's estimate is 1.5-fold (0.18 log units) above it, within the range that was stated.
By their numbers in this assay, from the lowest: compounds 3, 1 and 2 (each within the scatter of the next, the first and the last beyond it).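

In this assay the ring on a double-bonded chain carbon bound to a double-bonded chain carbon now gives a step beyond the scatter (a 3.2-fold lower number from compound 2 to compound 3 (0.50 log units; beyond the scatter)), while 3-fluoro-4-hydroxyphenyl in place of 4-fluorophenyl stays within it (a 1.7-fold lower number from compound 1 to compound 3 (0.23 log units; within the scatter)). This place therefore answers to the ring it carries, though the step is modest, and nothing available gives a reason for it. The compounds shown leave open what the hydroxyl and the fluorine each contribute, and how a ring bearing an amine or a carboxylic acid would read here.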